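Benzyl versus phenyl on the bromoacrylamide core

A few compounds are considered here, and "the series" means these few. Any claim that something is new, unique, unknown or untested is made for them only; others in the source may bear on it.

In a functional assay on CCRF-CEM cells (Homo sapiens) for inhibition, read by cell counting, with a stated time of 3 days (a lower number here means a stronger inhibitor, a higher number a weaker inhibitor), compound 3 `C=C(Br)C(=O)Nc1cccc(-c2cn3nc(-c4cccc(OC)c4)sc3n2)c1` gives 1200 nM, the lowest of the two numbers shown. Compound 1 `C=C(Br)C(=O)Nc1cccc(-c2cn3nc(Cc4ccc(Cl)cc4)sc3n2)c1` gives 3300 nM in this assay, a step beyond the scatter. Compound 2 `COc1ccc(Cc2nn3cc(-c4cccc(N)c4)nc3s2)cc1` reaches only the limit of >= 250000 nM in this assay. Among the measured compounds shown here, the one measured step, a 2.8-fold lower number from compound 1 to compound 3 (0.44 log units; beyond the scatter), replaces a benzyl-type group by an aryl group on the shared core and is modest in size. Compound 4 `C=C(Br)C(=O)Nc1cccc(-c2cn3nc(Cc4ccc(OC)cc4)sc3n2)c1` runs the other way: 4-methoxybenzyl in place of 3-methoxyphenyl on an aromatic carbon. That measured step is the only one that bears here, so a modest move to a higher number in this assay, roughly undoing it, is expected. Compound 4 is expected to give 3000 nM, within 1200 nM to 8000 nM. The expected step is a 2.5-fold higher number from compound 3 to compound 4 (0.40 log units; beyond the scatter).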

Compound 4, half-maximal inhibitory concentration: 2300 nM
For compound 4 the middle estimate is 1.3-fold (0.12 log units) above the measured one; the measured number falls inside the stated range.
By their numbers in this assay, from the lowest: compounds 3, 4 and 1 (each within the scatter of the next, the first and the last beyond it). At a limit, above all of these: compound 2.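

With 4-methoxybenzyl in place of 3-methoxyphenyl at this position, the result is a 1.9-fold higher number from compound 3 to compound 4 (0.28 log units; within the scatter), so this pair does not separate the benzyl-type group from the aryl group. Methoxy in place of chloro on the benzyl group gives a 1.4-fold lower number from compound 1 to compound 4 (0.16 log units; within the scatter), which leaves that change unresolved as well. (1-Bromoethenyl)carbonyl in place of hydrogen on the nitrogen gives an at least 100-fold lower number from compound 2 to compound 4 (2.03 log units; beyond the scatter), and this step is read against the value of compound 2, which is a limit: the limit of >= 250000 nM in this assay, at which 1 of the 4 values shown sits.

Open, as far as these compounds go, is how a carboxylic acid or a longer chain on this aromatic carbon would read in this assay.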